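Dropping a Methyl From Compound 1: Cytotoxicity Outlook

A few compounds are considered here, and "the series" means these few. Any claim that something is new, unique, unknown or untested is made for them only; others in the source may bear on it.

Compound 1, `CC1CCN(C(=O)CCCNC(=O)c2ccc(S(C)(=O)=O)c([N+](=O)[O-])c2)CC1`, joins the shared core through an amide to a chain ending in a piperidine ring. Its reading comes from an ADME assay on HepG2 cells (Homo sapiens) for cytotoxicity, read by CellTiter-Glo and ATP content, with a stated time of 72 h; a higher number here means that more compound is needed for the effect, a lower number that less compound is needed. In this assay compound 1 gives > 27000 nM, which is a limit of the assay rather than a number. Compound 2, `CN(CC(=O)N1CCN(c2ccccc2)CC1)C(=O)c1ccc(S(C)(=O)=O)c([N+](=O)[O-])c1`, gives > 27000 nM in this assay, again a limit. Compound 3, `CN(CC(=O)N1CCN(c2ccc(C(F)(F)F)cc2)CC1)C(=O)c1ccc(S(C)(=O)=O)c([N+](=O)[O-])c1`, gives 11900 nM. Among the measured compounds shown here, the one measured step between neighbours is an at least 2.2-fold lower number from compound 2 to compound 3 (0.35 log units; beyond the scatter). Two of the three readings sit at the limit of > 27000 nM in this assay, at which 2 of the 3 values shown sit.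

Compound 4, `CS(=O)(=O)c1ccc(C(=O)NCCCC(=O)N2CCCCC2)cc1[N+](=O)[O-]`, differs from compound 1 in one place: hydrogen in place of methyl on a saturated ring carbon. For the measured compounds named here, no measured step removes a methyl from a saturated ring, so the step from compound 2 to compound 3, which changes an aromatic substituent, does not bear directly on it. The step from compound 1 to compound 4 is therefore expected to be a step that the limit leaves unreadable from compound 1 to compound 4, within the scatter. For compound 4 the expected value is 30000 nM, with a range from 14000 nM to 80000 nM, most likely reported again as a limit.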

Compound 4, half-maximal effective concentration: > 27000 nM
Compound 4 was reported as a limit (the forecaster's own chance of this, stated with the estimate: 75%); the middle value lies beyond the limit too.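

Compound 1 and compound 4 both stand only as limits in this assay, so no step between them can be read: the limit of > 27000 nM in this assay, at which 3 of the 4 values shown sit.

The compounds shown leave open whether hydrogen in place of methyl on the saturated ring carbon changes this reading at all.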